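The source may report more compounds than this note shows. Statements on the series, on what has been measured and on what is new or still open speak of the compounds shown alone.

Measured in an ADME assay on cells (Lymphocyte, Homo sapiens) for cytotoxicity, read by MTT assay, with a stated time of 48 h; a lower number here means a stronger inhibitor, a higher number a weaker inhibitor:
- Compound 1 `COC(=O)/C(=C\c1ccc(OC(=O)c2ccccc2)cc1)Sc1ccnc2cc(Cl)ccc12`: > 100000 nM, a limit and not a number
- Compound 2 `COC(=O)/C(=C\c1ccc(OC(=O)c2ccccc2OC)cc1)Sc1ccnc2cc(Cl)ccc12`: > 100000 nM, a limit and not a number
- Compound 3 `COC(=O)/C(=C\c1ccc(OC(=O)c2ccc(OC)c(OC)c2)cc1)Sc1ccnc2cc(Cl)ccc12`: 51100 nM

Only compound 3 has a true number, while the other two sit at the limit of > 100000 nM in this assay, at which 2 of the 3 values shown sit.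

Compound 4 `COC(=O)/C(=C\c1ccc(OC(=O)c2c(OC)cccc2OC)cc1)Sc1ccnc2cc(Cl)ccc12` is built from the same atoms as compound 3, joined differently, with 2,6-dimethoxyphenyl in place of 3,4-dimethoxyphenyl on a carbonyl carbon.

Among the compounds with values here, three measured steps bear on this change. Adding a single methoxy gave a step that the two limits leave unreadable from compound 1 to compound 2, which says little. Changing the group on the same carbonyl carbon gave an at least 1.9-fold lower number from compound 1 to compound 3 (0.29 log units; that floor lies within the scatter) and also an at least 1.9-fold lower number from compound 2 to compound 3 (0.29 log units; that floor lies within the scatter). Going by these compounds, both are small, and their true sizes remain open. The group in compound 4 has two methoxy groups, like compound 3, but its pattern has more in common with compound 2, so part of an at least 1.9-fold lower number from compound 2 to compound 3 (0.29 log units; that floor lies within the scatter) is expected to be lost. A modestly higher number is therefore expected, and the expected size is a 1.7-fold higher number from compound 3 to compound 4 (0.22 log units; within the scatter). A result reported only as a limit is also quite possible. Compound 4 is estimated at 85000 nM, with an expected range of 40000 nM to 170000 nM.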

Compound 4, half-maximal inhibitory concentration: > 100000 nM
Compound 4: a limit, no number; the forecaster's own chance of this, stated with the estimate: 50%; at least 1.1-fold (0.07 log units) between middle value and limit.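

Swapping 3,4-dimethoxyphenyl for 2,6-dimethoxyphenyl on the carbonyl carbon keeps every atom yet gives an at least 1.9-fold higher number from compound 3 to compound 4 (0.29 log units; that floor lies within the scatter). Having two methoxy groups is therefore not enough on its own to give a true number in this set; how they are arranged on the ring may count, although the floor of that step lies within the scatter and its true size stays open. The steps to compound 4 from compound 1 and from compound 2 cannot be read, and most of the series now sits at a single limit: the limit of > 100000 nM in this assay, at which 3 of the 4 values shown sit.

Going by these compounds, how far apart the compounds at that limit truly lie remains unknown, and only compound 3 has a number. Also open, on these data alone, is whether an amine or a carboxylic acid on this ring, in place of a methoxy group, would give a lower number in this assay.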